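A few compounds are considered here, and "the series" means these few. Any claim that something is new, unique, unknown or untested is made for them only; others in the source may bear on it.

Measured so far:
Compound 1 `CCNC(=O)Nc1c(OCCCn2cnc(-c3ccccc3)c2)cccc1N(C)C` — > 10000 nM
Compound 2 `CCCCCC(=O)Nc1c(OCCCn2cnc(-c3ccccc3)c2)cccc1N(C)C` — 100 nM

Compound 1, `CCNC(=O)Nc1c(OCCCn2cnc(-c3ccccc3)c2)cccc1N(C)C`, is one of two measured compounds. In an assay on aorta for inhibition of acyl-CoA:cholesterol acyltransferase (Oryctolagus cuniculus) (a lower number here means a stronger inhibitor, a higher number a weaker inhibitor), compound 1 reaches only > 10000 nM, which is a limit of the assay and not a number. Compound 2, `CCCCCC(=O)Nc1c(OCCCn2cnc(-c3ccccc3)c2)cccc1N(C)C`, carries a pentyl in place of the ethylamino on the carbonyl carbon, and in this assay compound 2 gives 100 nM. Among the compounds with values here, that single change is the one measured step: an at least 100-fold lower number from compound 1 to compound 2 (2.00 log units; beyond the scatter), a step read against (the limit of > 10000 nM in this assay, at which 1 of the 2 values shown sits). Within the data shown here, compound 2 thus holds the only true number in the set; the other value is a limit.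

Compound 3, `CCCCCN(C)C(=O)Nc1c(OCCCn2cnc(-c3ccccc3)c2)cccc1N(C)C`, is not yet measured. It differs from compound 2 by methyl(pentyl)amino in place of pentyl on a carbonyl carbon. This partly undoes the measured step, since a nitrogen returns to the carbonyl carbon, as in compound 1, though now bearing methyl and pentyl rather than ethyl and a hydrogen. The measured step of an at least 100-fold lower number from compound 1 to compound 2 (2.00 log units; beyond the scatter) was large, so a rise in the number beyond the scatter is expected, though probably a smaller one, as the pentyl chain is kept.

Compound 3 is expected to give about 1000 nM, within a range of 200 nM to 10000 nM, an expected step of a 10-fold higher number from compound 2 to compound 3 (1.00 log units; beyond the scatter).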

Compound 3, half-maximal inhibitory concentration: 280 nM
Compound 3: the middle estimate sits 3.6-fold (0.55 log units) above what was measured, within the range that was stated.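

In this assay, a nitrogen on the carbonyl carbon does not by itself abolish inhibition, since methyl(pentyl)amino in place of ethylamino gives an at least 35-fold lower number from compound 1 to compound 3 (1.55 log units; beyond the scatter). The value of compound 1 is a limit of the assay and not a number, and that step is read against it: the limit of > 10000 nM in this assay, at which 1 of the 3 values shown sits.

Set against the pentyl group, methyl(pentyl)amino still gives a modest loss, a 2.8-fold higher number from compound 2 to compound 3 (0.45 log units; beyond the scatter), which is much smaller than the gap that separates ethylamino from either group carrying the pentyl chain.

The compounds shown change the chain and the methyl on the nitrogen together, so pentylamino and ethyl(methyl)amino on the same carbonyl carbon would be needed to tell which of the two changes carries the gain over compound 1. On these data alone, it also remains open how the number moves with a longer chain such as octyl, or with pentyloxy, where an oxygen takes the place of the nitrogen.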